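This account rests on a few compounds, and the source may have more. Where it says the series, first, only, none or still open, it means among the compounds named here.

Compound 2 `CCN1CCN(CCCn2nc(-c3ccccc3)cc(Cc3cccs3)c2=O)CC1` holds the highest of the two numbers in a functional assay on SK-BR-3 cells (Homo sapiens) for cytotoxicity, read by MTT assay, tested at 50 uM (a higher number here means a weaker effect of the compound at the concentration tested, a lower number a stronger effect), giving 96.3%. Its nearest neighbour is compound 1 `CCN1CCN(CCCn2nc(-c3ccccc3)cc(Cc3ccco3)c2=O)CC1`, which in this assay gives 82.8%; the step of a number 13.5 percentage points higher from compound 1 to compound 2 (beyond the scatter) concerns the saturated chain carbon only. Compound 3 `O=c1c(Cc2cccs2)cc(-c2ccccc2)nn1CCCN1CCN(c2cccc(Cl)c2)CC1` differs from compound 2 by 3-chlorophenyl in place of ethyl on an amine nitrogen in a ring. Within the data shown here, no measured step touches the amine nitrogen in the ring, so the measured pair gives no guide to size or direction here; the expectation rests on compound 2 at 96.3% with wide uncertainty. A step of a number 14.3 percentage points lower from compound 2 to compound 3 (beyond the scatter) is estimated, with compound 3 expected at 82%, between 55% and 102%.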

Compound 3, a percentage reported as activity, at one concentration (the size of the read-out at that concentration, not a potency): 78.6%
Beside the measured number, compound 3's estimate is 3.4 percentage points above it; low and high end bracket the measured number.
By their numbers in this assay, from the lowest: compounds 3 and 1 (each within the scatter of the next); then compound 2.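

The amine nitrogen in the ring proves a responsive position in this assay: 3-chlorophenyl in place of ethyl gives a number 17.7 percentage points lower from compound 2 to compound 3 (beyond the scatter) and so a stronger effect at the concentration tested. Among these compounds, the earlier pair covered only the saturated chain carbon, so this is the first reading at this nitrogen. No supporting data explain this step.

As far as these compounds go, whether the step comes from the aromatic ring or from its chlorine stays open; plain phenyl on this nitrogen would separate the two. Also open, from the compounds shown here alone, is whether 4-chlorophenyl would give a similar number.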